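The compounds below may be only part of what the source reports. "The series", "measured", "known", "first", "only" and "open" are said of these compounds alone.

Compound 1 `N#Cc1ccc(N2CCCc3c(-c4cccnc4)cccc32)cc1C(F)(F)F` and compound 2 `CCN(c1ccc(C#N)c(Cl)c1)c1cc(-c2ccoc2)ccc1C` were both tested in a functional assay on CWR22R cells (Homo sapiens) for antiproliferative activity, read by CCK-8 assay, with a stated time of 6 days; on this read-out lower numbers stand for stronger inhibition and higher numbers for weaker inhibition. In this assay compound 1 gives 12300 nM. Compound 2 reaches only a limit of the assay, > 30000 nM. Compound 2 therefore stands at the limit of > 30000 nM in this assay, at which 1 of the 2 values shown sits. Compound 3 `CCN(c1ccc(C#N)c(Cl)c1)c1cc(-c2cncnc2)ccc1C` differs from compound 2 by pyrimidin-5-yl in place of furan-3-yl on an aromatic carbon. Within the data shown here, no measured pair shows this change, so its size is open, and a step staying within the scatter would again leave compound 3 at a limit. The step from compound 2 to compound 3 is expected to be a step that the limit leaves unreadable from compound 2 to compound 3. Compound 3 is estimated at 35000 nM, within 12000 nM to 100000 nM, most likely reported only as a limit.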

Compound 3, half-maximal inhibitory concentration: > 30000 nM
Compound 3: a limit, no number; the forecaster's own chance of this, stated with the estimate: 65%; the middle value lies beyond the limit too.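

No step can be read between compound 2 and compound 3, since both stand only at a limit: the limit of > 30000 nM in this assay, at which 2 of the 3 values shown sit.

The compounds shown leave open how much pyrimidin-5-yl in place of furan-3-yl changes the antiproliferative activity.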